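Sulfamoylurea series: amide aryl variation and blood activity

The compounds below may be only part of what the source reports. "The series", "measured", "known", "first", "only" and "open" are said of these compounds alone.

Working notes on a functional assay on the whole organism (blood) with Rattus norvegicus as the target, with stated times of 24 h and 1 h, at a dose of 5 mg/kg by the intraperitoneal route; a higher number here means a stronger effect of the compound at the dose given, a lower number a weaker effect. Compound 1 `COc1ccc(Cl)cc1C(=O)NCCC1CCN(S(=O)(=O)NC(=O)NC2CCCCC2)CC1` gives 25%, compound 3 `O=C(NC1CCCCC1)NS(=O)(=O)N1CCC(CCNC(=O)c2cccc3cccnc23)CC1` gives 37%, and compound 2 `CC(=O)NCCC1CCN(S(=O)(=O)NC(=O)NC[C@@H]2C[C@@H]3C=C[C@@H]2C3)CC1` gives 18%, the lowest of the three numbers, within the scatter of compound 1 and beyond it against compound 3. Compound 4 `O=C(NC[C@@H]1C[C@@H]2C=C[C@@H]1C2)NS(=O)(=O)N1CCC(CCNC(=O)c2cccc3c2OCCO3)CC1` differs from compound 2 by 2,3-dihydro-1,4-benzodioxin-5-yl in place of methyl on a carbonyl carbon. For the measured compounds named here, the only measured step on a carbonyl carbon is a number 12 percentage points higher from compound 1 to compound 3 (beyond the scatter), an exchange of one aromatic group for another and so only partly comparable. Compound 3, carrying an aromatic ring on that carbon, stands beyond the scatter above compound 2 with its acetyl, while compound 1 lies within it. A modest rise is therefore expected, a number 12 percentage points higher from compound 2 to compound 4 (beyond the scatter). Compound 4 is estimated at 30%, between 15% and 45%.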

Compound 4, a percentage reported as activity, at one dose (the size of the read-out at that dose, not a potency): 11%
For compound 4 the middle estimate is 19 percentage points above the measured one, outside the stated range (below it).
By their numbers in this assay, from the lowest: compounds 4, 2 and 1 (each within the scatter of the next, the first and the last beyond it); then compound 3.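

In this assay, the exchange on this carbonyl carbon gives a number 7 percentage points lower from compound 2 to compound 4 (within the scatter). Going from methyl to 2,3-dihydro-1,4-benzodioxin-5-yl adds 10 heavy atoms in place of 1 and brings in two rings, yet the result stays within the scatter, so on this core the fused aromatic group brings no measurable gain over methyl. Nothing at hand bears on why this exchange leaves the read-out within the scatter.

Going by these compounds, whether a plain phenyl ring or a longer alkyl chain on this carbonyl carbon would move the number beyond the scatter remains open. Also open, on these data alone, is whether the same exchange would behave alike in compounds carrying cyclohexyl on the urea.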